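Removing a Pyrazole Methyl from the Strongest Binder

The source may report more compounds than this note shows. Statements on the series, on what has been measured and on what is new or still open speak of the compounds shown alone.

Compound 1 `Cc1c(Nc2nc(N)c3c(C#N)c(N4CCC[C@H]4C)n(C)c3n2)cnn1C`: 2 nM
Compound 2 `CN(C)c1c(C#N)c2c(N)ncnc2n1C`: 111 nM
Compound 3 `Cn1c(N)c(C#N)c2c(N)ncnc21`: 346 nM

Of the compounds shown here, three have been measured in an assay on isolated protein for binding affinity to Leucine-rich repeat serine/threonine-protein kinase 2 (Homo sapiens), read by TR-FRET and LanthaScreen, with a stated time of 2 h; on this read-out lower numbers stand for stronger inhibition and higher numbers for weaker inhibition. Compound 1 gives the lowest number of the three, and its gaps to compound 2 and to compound 3 both lie beyond the usual scatter, so on these numbers compound 1 is the strongest binder. Within the data shown here, the single step between measured compounds that differ in one place is a 3.1-fold higher number from compound 2 to compound 3 (0.49 log units; beyond the scatter), which concerns the amino group on the shared core.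

Compound 4 `C[C@@H]1CCCN1c1c(C#N)c2c(N)nc(Nc3cnn(C)c3)nc2n1C` is the next compound to be measured in this assay. It differs from compound 1 by hydrogen in place of methyl on an aromatic carbon. Among the measured compounds shown here, none of the measured steps touches this part of the molecule: the step from compound 2 to compound 3 changes a group on the core, not the pyrazole, so it gives no direct guide to the size or direction of the present change. Because compound 1 gives 2 nM and the change is the loss of a single carbon, compound 4 is expected to stay close to it, with a step of a 1.5-fold higher number from compound 1 to compound 4 (0.18 log units; within the scatter) that may well fall within the scatter. The estimate for compound 4 in this assay is 3 nM, with a range from 1 nM to 10 nM.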

Compound 4, inhibition constant: 0.1 nM
Compound 4: middle estimate off by 30-fold (1.48 log units), on the high side; measured number below the stated range.
By their numbers in this assay, from the lowest: compound 4; then compound 1; then compound 2; then compound 3.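

In this assay the change from 1,5-dimethyl-1H-pyrazol-4-yl to 1-methyl-1H-pyrazol-4-yl gives a 20-fold lower number from compound 1 to compound 4 (1.30 log units; beyond the scatter) and so shows that this methyl, on an aromatic carbon next to the ring nitrogen and next to the ring atom that bears a large group, has a large bearing on the number and that the number falls when hydrogen takes its place. Among these compounds, compound 2 and compound 3 carry no such ring, and the only earlier step, a 3.1-fold higher number from compound 2 to compound 3 (0.49 log units; beyond the scatter) for amino in place of dimethylamino on the shared core, said nothing about this position and is smaller than the new step, even though the new change exchanges only a methyl for a hydrogen. No measurement given here explains why the methyl costs so much in this series.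

Only methyl and hydrogen are shown at this position, so it stays open how a fluorine, an ethyl, a methoxy or an amine there would compare with either. As far as these compounds go, it also stays open whether hydrogen in place of methyl here would give a step of similar size and direction with other groups on the shared core.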